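This account rests on a few compounds, and the source may have more. Where it says the series, first, only, none or still open, it means among the compounds named here.

Measured so far:
Compound 1, `O=C(O)/C=C/c1ccncc1-c1ccc2cc[nH]c2c1`, gives > 30000 nM in a functional assay on HCT-116 cells (Homo sapiens) for inhibition, read by MTT assay, with a stated time of 72 h; a higher number here means a weaker inhibitor of growth, a lower number a stronger inhibitor of growth; this is a limit of the assay, not a number.
Compound 2, `CCOC(=O)/C=C/c1ccncc1-c1ccc2c(ccn2C)c1`, gives 210 nM in this assay.
Compound 3, `CC(C)[C@@H](NC(=O)/C=C/c1ccncc1-c1ccc2ccccc2c1)C(=O)O`, is recorded as "not determined" (no result reported) in this assay.

Compound 3 therefore stands nowhere on the numbers shown: the only result given for it is that none was determined, so it can be placed neither next to the limit of compound 1 nor next to the figure of compound 2. The change from compound 3 to compound 4, `CNC(=O)/C=C/c1ccncc1-c1ccc2ccccc2c1`, is methyl in place of 1-carboxy-2-methylpropyl on an amide-type nitrogen. Among the compounds with values here, since no measured pair of compounds covers a step of this kind, the size of the step in this assay cannot be read from the data, and no direction can be claimed. What the two measured values do show is that compound 1 sits at the limit of > 30000 nM in this assay, at which 1 of the 3 values shown sits, whereas compound 2 is a clear inhibitor of growth. Compound 4, like compound 2, carries no carboxy group, so it is expected to land nearer the figure of compound 2 than the limit of compound 1. Compound 4 is estimated at 600 nM, within a range from 100 nM to 5000 nM.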

Compound 4, concentration for 50% growth inhibition: 6550 nM
Compound 4: middle estimate off by 11-fold (1.04 log units), on the low side; the measured number lies above the stated range.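

Compound 3 carries no number in this assay, so no step to compound 4 can be read, and nothing shown bears on the result of compound 4. The compounds shown leave open how changing the group on the amide-type nitrogen shifts the values in this assay.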